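Piperazine amide variation and inhibition of monoamine oxidase A

A few compounds are considered here, and "the series" means these few. Any claim that something is new, unique, unknown or untested is made for them only; others in the source may bear on it.

Measured so far:
compound 1, `CC(=O)NC[C@H]1CN(c2ccc(-c3ccc(/C=N/N4CCNCC4)cc3)c(F)c2)C(=O)O1`, 84%
compound 2, `CC(=O)NC[C@H]1CN(c2ccc(-c3ccc(/C=N/N4CCN(C(=O)c5ccc(F)cc5)CC4)cc3)c(F)c2)C(=O)O1`, 89%

The series shares the core of compound 1, and both members were tested in an ADME assay on Sf9 cells for inhibition of Amine oxidase [flavin-containing] A (Homo sapiens), read by luminescence, with stated times of 15 min and 60 min, tested at 30 uM; on this read-out lower numbers stand for less inhibition and higher numbers for more inhibition at the one concentration tested (going by the name of the read-out). Compound 1 gives 84%; compound 2 gives 89%. Among the measured compounds shown here, the only step available is a number 5 percentage points higher from compound 1 to compound 2 (within the scatter), so compound 2 stands together with compound 1 rather than apart from it.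

Compound 3, `CC(=O)NC[C@H]1CN(c2ccc(-c3ccc(/C=N/N4CCN(C(=O)CO)CC4)cc3)c(F)c2)C(=O)O1`, is not yet measured. It differs from compound 2 by hydroxymethyl in place of 4-fluorophenyl on a carbonyl carbon. This change sits on the same amine nitrogen in a ring that was varied between compound 1 and compound 2, where a hydrogen became a (4-fluorophenyl)carbonyl with only a number 5 percentage points higher from compound 1 to compound 2 (within the scatter). That step is the one that bears on the present case: a larger group on that nitrogen left the read-out where it was, so a smaller (hydroxymethyl)carbonyl in its place is expected to leave it there as well. For compound 3 the expected step is therefore a number 4 percentage points lower from compound 2 to compound 3 (within the scatter), none beyond the scatter. Compound 3 is estimated at 85%, with a range from 70% to 95%.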

Compound 3, a percentage reported as inhibition, at one concentration (the size of the read-out at that concentration, not a potency): 80%
The estimate for compound 3 lay 5 percentage points above the measured number, within the range that was stated.
By their numbers in this assay, from the lowest: compounds 3, 1 and 2 (each within the scatter of the next).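

In this assay the exchange of 4-fluorophenyl for hydroxymethyl on a carbonyl carbon gives a number 9 percentage points lower from compound 2 to compound 3 (within the scatter) even though the aromatic ring leaves and 1 hydrogen-bond donor and 1 hydrogen-bond acceptor enter, so the number stays level for a change of group on the carbonyl as well as for the addition of a carbonyl group to the amine nitrogen. Measured against the unsubstituted piperazine of compound 1, (hydroxymethyl)carbonyl in place of hydrogen on an amine nitrogen in a ring gives a number 4 percentage points lower from compound 1 to compound 3 (within the scatter) and so adds a second acylated member that reads alike with the parent, which makes all three compounds indistinguishable in this assay at the one concentration tested. No supporting measurement is at hand to account for this flat reading.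

The three compounds leave open whether any group on this nitrogen moves the read-out beyond the scatter, for instance a carboxylic acid, an aminoacetyl group or a longer chain on the carbonyl. A read-out at one concentration gives only the size of the effect at that concentration and also leaves open whether compound 1, compound 2 and compound 3 would still read alike at other concentrations.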